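The compounds below may be only part of what the source reports. "The series", "measured", "known", "first", "only" and "open" are said of these compounds alone.

Compound 2 `O=c1cc(N2CCN(CC3CCC(O)CC3)CC2)sc2c([N+](=O)[O-])cc(C(F)(F)F)cc12` carries a hydroxy on the saturated ring carbon and gives 51.2% in an ADME assay on cells (Hepatocyte, Mus musculus) for metabolic stability, with a stated time of 30 min; on this read-out higher numbers stand for a more stable compound and lower numbers for a less stable compound. Among the three measured compounds it stands lowest. Compound 1 `NC1CCC(CN2CCN(c3cc(=O)c4cc(C(F)(F)F)cc([N+](=O)[O-])c4s3)CC2)CC1`, with amino in that place, gives 107% in this assay, and compound 3 `CC(=O)NC1CCC(CN2CCN(c3cc(=O)c4cc(C(F)(F)F)cc([N+](=O)[O-])c4s3)CC2)CC1`, with acetamido there, gives 94.9%. The step of a number 55.8 percentage points lower from compound 1 to compound 2 (beyond the scatter) and the step of a number 43.7 percentage points higher from compound 2 to compound 3 (beyond the scatter) are both large and beyond the scatter, while the step of a number 12.1 percentage points lower from compound 1 to compound 3 (beyond the scatter) is modest.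

Compound 4 `O=C(OC1CCC(CN2CCN(c3cc(=O)c4cc(C(F)(F)F)cc([N+](=O)[O-])c4s3)CC2)CC1)c1ccccc1` is not yet measured. It differs from compound 2 in one place: benzoyl in place of hydrogen on an oxygen on a saturated carbon. Both measured steps that leave compound 2, to compound 1 and to compound 3, run upward, and the nearest comparison is the step to compound 3, in which the hydroxy is replaced by acetamido. Going by the values given here, no measured step covers a benzoyl on oxygen, so that analogy carries limited weight, and the range has to stay wide.

On this basis compound 4 is expected to give 62% in this assay, within 25% to 95%. The expected step is therefore a number 10.8 percentage points higher from compound 2 to compound 4 (beyond the scatter), upward, though the estimate is held loosely.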

Compound 4, percent of the compound remaining: 68.1%
For compound 4 the middle estimate is 6.1 percentage points below the measured one; low and high end bracket the measured number.
By their numbers in this assay, from the lowest: compound 2; then compound 4; then compound 3; then compound 1.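

Working notes on the saturated ring carbon: in this assay, the free hydroxy is not the low end for an oxygen at this position, since benzoyl on that oxygen gives a number 16.9 percentage points higher from compound 2 to compound 4 (beyond the scatter). Even so, the benzoyloxy group does not reach either nitrogen-linked group, with a number 26.8 percentage points lower from compound 3 to compound 4 (beyond the scatter) and, against the free amino group, a number 38.9 percentage points lower from compound 1 to compound 4 (beyond the scatter). Across these four compounds, the two groups attached through nitrogen therefore stand above the two attached through oxygen, and no compound shown goes against that order, although four compounds at one position make only a narrow basis for it.

The compounds shown leave open whether the rise belongs to acylation of the oxygen in general or to benzoyl in particular, which an acetoxy group at this carbon would test directly against the acetamido group of compound 3. They also leave the linking atom unseparated from the acyl group, and a benzamido group would pair with compound 4 to make that comparison.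

Nothing at hand offers an explanation for these differences.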